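The source may hold more compounds than are shown below. What is called first, only, known or untested is meant among the compounds shown, and "the series" means these compounds.

Compounds measured in an ADME assay on HT-29 cells (Homo sapiens) for cytotoxicity, read by MTT assay, with a stated time of 72 h; on this read-out higher numbers stand for weaker inhibition and lower numbers for stronger inhibition:
- compound 1 `C=CC(=O)Nc1cc(Nc2ncc3ncn(-c4ccc(CC)cc4)c3n2)c(OC)cc1N(C)CCN(C)C`: 8180 nM
- compound 2 `C=CC(=O)Nc1cc(Nc2ncc3ncn(-c4ccc(I)cc4)c3n2)c(OC)cc1N(C)CCN(C)C`: 9520 nM
- compound 3 `C=CC(=O)Nc1cc(Nc2ncc3ncn(-c4ccccc4Br)c3n2)c(OC)cc1N(C)CCN(C)C`: 16200 nM

Compound 3 carries the highest of the three numbers in this assay, yet neither of its neighbours is separated from it beyond the scatter: a 2.0-fold higher number from compound 1 to compound 3 (0.30 log units; within the scatter) and a 1.7-fold higher number from compound 2 to compound 3 (0.23 log units; within the scatter). The three compounds are therefore read as one group with no resolved difference among them.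

Compound 4 `C=CC(=O)Nc1cc(Nc2ncc3ncn(-c4ccc(Cl)cc4Cl)c3n2)c(OC)cc1N(C)CCN(C)C` is not yet measured in this assay. It differs from compound 3 in one place: 2,4-dichlorophenyl in place of 2-bromophenyl on an aromatic nitrogen. The measured steps that bear on this change are those that also swap the aryl group on the same aromatic nitrogen, namely a 2.0-fold higher number from compound 1 to compound 3 (0.30 log units; within the scatter) and a 1.7-fold higher number from compound 2 to compound 3 (0.23 log units; within the scatter), both within the scatter, alongside a 1.2-fold higher number from compound 1 to compound 2 (0.07 log units; within the scatter). Three exchanges on that aryl group have left the number where it was, so no step beyond the scatter is expected for a 1.2-fold lower number from compound 3 to compound 4 (0.10 log units; within the scatter) either. Compound 4 is expected to give about 13000 nM in this assay, with a range from 6000 nM to 32000 nM.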

Compound 4, half-maximal inhibitory concentration: 20600 nM
Beside the measured number, compound 4's estimate is 1.6-fold (0.20 log units) below it; measured number inside the range.
By their numbers in this assay, from the lowest: compounds 1, 2, 3 and 4 (each within the scatter of the next, the first and the last beyond it).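

In this assay, for the compounds shown here, exchanges of the aryl group on the aromatic nitrogen now give the first steps beyond the scatter, both modest: a 2.2-fold higher number from compound 2 to compound 4 (0.34 log units; beyond the scatter) and a 2.5-fold higher number from compound 1 to compound 4 (0.40 log units; beyond the scatter). The direct exchange of 2-bromophenyl for 2,4-dichlorophenyl stays unresolved, a 1.3-fold higher number from compound 3 to compound 4 (0.10 log units; within the scatter), and compound 3 goes against any clean split of the series, as it lies within the scatter of compound 1, compound 2 and compound 4. The position therefore responds to the aryl group only across the two widest exchanges, and no evidence bearing on the origin of these steps is available.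

As far as these compounds go, whether a single chlorine, as in 2-chlorophenyl or 4-chlorophenyl, is enough for such a step remains open. Also open, from the compounds shown here alone, is how an aryl group carrying an amine or a carboxylic acid would read in this assay.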